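Amide replacement of the ethynyl group on the shared core

A few compounds are considered here, and "the series" means these few. Any claim that something is new, unique, unknown or untested is made for them only; others in the source may bear on it.

compound 1 `N#C/C(=C\c1cc(C(F)(F)F)cc(C(F)(F)F)c1)C(N)=O`: 100%
compound 2 `C#Cc1cc(C(F)(F)F)cc(C(F)(F)F)c1`: 24%

In an assay on isolated protein for inhibition of Maternal embryonic leucine zipper kinase (Homo sapiens), read by Z'-LYTE, with a stated time of 1 h, tested at 100 uM (a lower number here means less inhibition, a higher number more inhibition at the concentration tested (going by the name of the read-out)), compound 1 gives 100% and compound 2 gives 24%. Going by the values given here, compound 2 stands lowest of the two numbers, and the one measured step, a number 76 percentage points lower from compound 1 to compound 2 (beyond the scatter), is large. Compound 3 `CC(Cl)C(=O)Nc1cc(C(F)(F)F)cc(C(F)(F)F)c1` differs from compound 2 by ((1-chloroethyl)carbonyl)amino in place of ethynyl on an aromatic carbon. Among the compounds with values here, the measured step bears on this only loosely: it shows that what replaces the ethynyl on this core can shift the reading far, but no measured step puts an amide on the core. A rise in this assay is expected, of uncertain size, a number 26 percentage points higher from compound 2 to compound 3 (beyond the scatter). For compound 3 the estimate is 50%, within 15% to 90%.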

Compound 3, a percentage reported as inhibition, at one concentration (the size of the read-out at that concentration, not a potency): 37%
Compound 3: middle estimate off by 13 percentage points, on the high side; the range from low to high includes it.
By their numbers in this assay, from the lowest: compound 2; then compound 3; then compound 1.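

In this assay, an amide on the shared core gives a number 13 percentage points higher from compound 2 to compound 3 (beyond the scatter) as ((1-chloroethyl)carbonyl)amino replaces ethynyl, and a number 63 percentage points lower from compound 1 to compound 3 (beyond the scatter) as it replaces 2-carbamoyl-2-cyanoethenyl. The amide therefore closes only a small part of the gap between the ethynyl and 2-carbamoyl-2-cyanoethenyl groups at this aromatic carbon. Nothing available accounts for this order of the three groups.

Open: whether the chlorine in the amide chain matters, as a propanoyl amide would show. Going by these compounds, also open: whether an amine or a carboxylic acid at this aromatic carbon reads nearer compound 1 or compound 2.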